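A few compounds are considered here, and "the series" means these few. Any claim that something is new, unique, unknown or untested is made for them only; others in the source may bear on it.

Measured so far in a physicochemical assay for solubility, read by HPLC, measured as kinetic solubility, with a stated time of 24 h, at pH 6.5; on this read-out lower numbers stand for lower solubility and higher numbers for higher solubility:
Compound 1 `CC(C)(C)NCc1cc(Cl)cc(Nc2nc3ccccc3n2Cc2ccc(C(F)(F)F)cc2)c1O`: < 5000 nM
Compound 2 `CCN(CC)Cc1cc(C)cc(Nc2nc3ccccc3n2Cc2ccc(C(F)(F)F)cc2)c1O`: < 5000 nM

Neither of these entries is a number. For compound 2 the result, < 5000 nM, is a limit of the assay. Compound 1 likewise returns a limit, < 5000 nM. Within the data shown here, the record therefore consists of the limit of < 5000 nM in this assay, at which 2 of the 2 values shown sit, and no step between measured compounds can be read from it.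

Compound 3 `Cc1cc(CNC(C)(C)C)c(O)c(Nc2nc3ccccc3n2Cc2ccc(C(F)(F)F)cc2)c1` has not yet been measured. It has the same atoms as compound 2, joined differently: (tert-butyl)amino in place of diethylamino on a saturated chain carbon bound to an aromatic carbon. In words, (tert-butyl)amino stands in place of diethylamino on a saturated chain carbon bound to an aromatic carbon.

The expectation rests on compound 2, whose < 5000 nM is a limit. The expected change, a step that the limit leaves unreadable from compound 2 to compound 3, is none beyond the usual scatter, in either direction, and this is only a loose estimate. The result in this assay may well be a limit again. Compound 3 is estimated at 3500 nM, with an expected range from 1200 nM to 6000 nM.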

Compound 3, solubility: 50000 nM
Estimate against measurement, compound 3: 14-fold (1.15 log units) below, outside the stated range (above it).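

In this assay, among these compounds, (tert-butyl)amino in place of diethylamino on a saturated chain carbon bound to an aromatic carbon goes with an at least 10-fold higher number from compound 2 to compound 3 (1.00 log units; beyond the scatter), while methyl in place of chloro on an aromatic carbon goes with an at least 10-fold higher number from compound 1 to compound 3 (1.00 log units; beyond the scatter), so these are the first readable steps. Neither group goes with a readable number by itself: compound 1 already carries (tert-butyl)amino and compound 2 already carries methyl, and only compound 3, which has both together, stands clear of the limit. Each step gives only a minimum size, because its starting point is not a number: the limit of < 5000 nM in this assay, at which 2 of the 3 values shown sit.

From the compounds shown here alone, no step can be read between compound 1 and compound 2, so how the two changes combine, and how much each contributes, stays open. Also open, going by these compounds, is whether another amine on the saturated chain carbon, such as isopropylamino or a longer chain amine, or another group on the aromatic carbon, such as bromo or methoxy, would go with a number as high as that of compound 3.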